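Working notes on cytotoxicity across compounds 1 to 4

The compounds below may be only part of what the source reports. "The series", "measured", "known", "first", "only" and "open" are said of these compounds alone.

Compound 1 `CCN(CC)CC(=O)OC1CC2(N(C)C)CC(c3ccccc3)C1C(c1ccccc1)C2`, compound 2 `CCN(CC)CC(=O)OC1CC2(N3CCCCC3)CC(c3ccccc3)C1C(c1ccccc1)C2` and compound 3 `CCN(CC)CC(=O)OC1CC2(N3CCCC3)CC(c3ccccc3)C1C(c1ccccc1)C2` share one core and differ only in the amine on the saturated ring carbon. In an ADME assay on L6 cells (Rattus norvegicus) for cytotoxicity, with a stated time of 72 h (a higher number here means a weaker inhibitor, a lower number a stronger inhibitor), compound 1 gives 30100 nM, compound 2 gives 23900 nM and compound 3 gives 49000 nM. The steps of a 1.3-fold lower number from compound 1 to compound 2 (0.10 log units; within the scatter) and a 1.6-fold higher number from compound 1 to compound 3 (0.21 log units; within the scatter) lie within the scatter, while a 2.1-fold higher number from compound 2 to compound 3 (0.31 log units; beyond the scatter) is modest but beyond it. Compound 3 thus stands at the highest number of the three, though its gap to compound 1 is within the scatter.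

Compound 4 `OC1CC2(N3CCCC3)CC(c3ccccc3)C1C(c1ccccc1)C2` differs from compound 3 by hydrogen in place of ((diethylamino)methyl)carbonyl on an oxygen on a saturated carbon. None of the three measured steps touches this part of the molecule; each of them varies the amine on the saturated ring carbon, and the ester is kept throughout. Going by the values given here, no measured step therefore bears on the change, and no direction can be read from the data. The expected step in this assay is a 1.1-fold higher number from compound 3 to compound 4 (0.05 log units; within the scatter), which is meant as no step beyond the scatter, with a wide range. Compound 4 is estimated at 55000 nM, expected between 18000 nM and 170000 nM.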

Compound 4, half-maximal inhibitory concentration: 26800 nM
Beside the measured number, compound 4's estimate is 2.1-fold (0.31 log units) above it, within the range that was stated.
By their numbers in this assay, from the lowest: compounds 2, 4, 1 and 3 (each within the scatter of the next, the first and the last beyond it).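

At this oxygen on a saturated carbon, this assay gives a 1.8-fold lower number from compound 3 to compound 4 (0.26 log units; within the scatter) as the only step shown, so hydroxy in place of (((diethylamino)methyl)carbonyl)oxy leaves compound 4 within the scatter of compound 3. With pyrrolidin-1-yl kept on the saturated ring carbon, the whole ((diethylamino)methyl)carbonyl group can therefore go without a step beyond the scatter in this read-out. Nothing at hand gives a reason for this result.

Whether the same holds with dimethylamino or piperidin-1-yl on the saturated ring carbon stays open, since the compounds shown pair the hydroxy group only with pyrrolidin-1-yl. Also open, going by these compounds, is how a plain acetyl group, or a longer chain between the carbonyl and the diethylamino nitrogen, would read on this oxygen.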